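Notes on three aryl variants and a fourth to come

This account rests on a few compounds, and the source may have more. Where it says the series, first, only, none or still open, it means among the compounds named here.

Measured compounds:
compound 1 `Nc1scc(CN2CCN(c3ccc(F)cc3Cl)CC2)c1C(=O)c1ccc(Cl)cc1` — 0%
compound 2 `COc1ccc(N2CCN(Cc3csc(N)c3C(=O)c3ccc(Cl)cc3)CC2)cc1` — 0%
compound 3 `Nc1scc(CN2CCN(c3ccc([N+](=O)[O-])cc3)CC2)c1C(=O)c1ccc(Cl)cc1` — 2%

In an assay on CHO cells for displacement of a labelled ligand from adenosine receptor A3 (Homo sapiens), read by scintillation counting, with a stated time of 120 min, tested at 10 uM (on this read-out lower numbers stand for less inhibition and higher numbers for more inhibition at the one concentration tested (going by the name of the read-out)), all three compounds sit within the usual scatter of one another, so none of their numbers can be called higher or lower than another. Changing the aryl group on the amine nitrogen in the ring gives no change at the digits printed from compound 1 to compound 2 (within the scatter) and a number 2 percentage points higher from compound 1 to compound 3 (within the scatter); swapping the substituent on that aryl ring gives a number 2 percentage points higher from compound 2 to compound 3 (within the scatter). Compound 3 therefore stands at a number indistinguishable from compound 1 and compound 2.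

Compound 4 `Nc1scc(CN2CCN(c3ccc(OC(F)(F)F)cc3)CC2)c1C(=O)c1ccc(Cl)cc1` differs from compound 3 by trifluoromethoxy in place of nitro on an aromatic carbon. The step from compound 2 to compound 3, the closest analogy, changed nothing beyond the scatter, and no aryl variation has yet moved the read-out. For compound 4 no step beyond the scatter is expected, no change at the digits printed from compound 3 to compound 4 (within the scatter). The estimate for compound 4 is 2%, between 0% and 12%.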

Compound 4, a percentage reported as inhibition, at one concentration (the size of the read-out at that concentration, not a potency): 1%
Compound 4: the middle estimate sits 1 percentage points above what was measured, and the stated range covers the measured number.
By their numbers in this assay, from the lowest: compounds 1, 2, 4 and 3 (each within the scatter of the next).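

In this assay, trifluoromethoxy on this aromatic carbon gives a number 1 percentage points lower from compound 3 to compound 4 (within the scatter), trifluoromethyl in place of methyl on the oxygen gives a number 1 percentage points higher from compound 2 to compound 4 (within the scatter), and the full aryl exchange gives a number 1 percentage points higher from compound 1 to compound 4 (within the scatter). Trifluoromethoxy therefore joins methoxy and nitro at this place, para to a large group, with no separation among the compounds. No available evidence bears on this flat result.

Open, from the compounds shown here alone, is whether an amine or a carboxylic acid on this aromatic carbon would separate from these compounds. Also open, going by these compounds, is whether any change to the shared core outside the aryl group would move the number.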